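A few compounds are considered here, and "the series" means these few. Any claim that something is new, unique, unknown or untested is made for them only; others in the source may bear on it.

Of the compounds shown here, two carry numbers so far. In a functional assay on A549 cells (Homo sapiens) for inhibition, read by CCK-8 assay, with a stated time of 72 h, tested at 2 uM (on this read-out lower numbers stand for less inhibition of growth and higher numbers for more inhibition of growth at the one concentration tested), compound 1 `Nc1ccccc1NC(=O)/C=C/c1ccc(CSc2ccc(Cl)cc2)cc1` gives 55.3%. Compound 2 `Cc1ccc(SCc2ccc(C(=O)Nc3ccccc3N)cc2)cc1` gives 40.5% in this assay, the lowest of the two numbers; its nearest neighbour is compound 1, which sits higher by a gap beyond the scatter. The two compounds differ in more than one place, so that gap is not tied to any single change. Compound 3 `CCc1ccc(SCc2ccc(C(=O)Nc3ccccc3N)cc2)cc1` has not yet been measured. It departs from compound 2 by one change, (methyl in place of hydrogen on a saturated chain carbon bound to an aromatic carbon), so that the 4-methylphenyl becomes a 4-ethylphenyl. For the measured compounds named here, no step between measured compounds covers a change of this kind, so nothing in the numbers points to a direction; the step in this assay is expected to be small, a number 2.5 percentage points higher from compound 2 to compound 3 (within the scatter), within the usual scatter. Compound 3 is accordingly expected to give about 43% in this assay, in the range 28% to 58%.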

Compound 3, percent growth inhibition at one concentration: 53.6%
Estimate against measurement, compound 3: 10.6 percentage points below; measured number inside the range.
By their numbers in this assay, from the lowest: compound 2; then compounds 3 and 1 (each within the scatter of the next).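

In this assay, for the compounds shown here, the change from 4-methylphenyl to 4-ethylphenyl gives a number 13.1 percentage points higher from compound 2 to compound 3 (beyond the scatter) and so provides the first step tied to a single place. A methyl in place of hydrogen on a saturated chain carbon bound to an aromatic carbon is therefore enough to move growth inhibition beyond the scatter at the one concentration tested. Nothing at hand accounts for this step.

On these data alone, whether a longer chain such as propyl, or a branched one such as isopropyl, would extend or reverse this rise remains open, as does the effect of an amine or a carboxylic acid at the same place. With one step available, it is also unknown whether this change would move the number the same way on another core.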